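This account rests on a few compounds, and the source may have more. Where it says the series, first, only, none or still open, it means among the compounds named here.

In an ADME assay on MT2 cells (Homo sapiens) for cytotoxicity (a lower number here means that less compound is tolerated, a higher number that more compound is tolerated), compound 1 `Cc1cc(C#N)cc(C)c1Oc1cc(Nc2ccc(C#N)cc2)c(N)cc1CNC1CC1` gives 12100 nM and compound 2 `Cc1cc(C#N)cc(C)c1Oc1cc(Nc2ccc(C#N)cc2)c(N)cc1CNCCCO` gives 15100 nM. Among the measured compounds shown here, compound 2 therefore stands level with compound 1, the only other measured compound, as the single measured step shows: a 1.2-fold higher number from compound 1 to compound 2 (0.10 log units; within the scatter). That step put 3-hydroxypropyl in place of cyclopropyl on an amine nitrogen.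

Compound 3 `CC(=O)OCc1cc(N)c(Nc2ccc(C#N)cc2)cc1Oc1c(C)cc(C#N)cc1C` goes further: acetoxy in place of (3-hydroxypropyl)amino on a saturated chain carbon bound to an aromatic carbon. In words, this is acetoxy in place of (3-hydroxypropyl)amino on a saturated chain carbon bound to an aromatic carbon. The measured step bears on this change only loosely, since both measured compounds keep the amine nitrogen and compound 3 lacks it. For the measured compounds named here, no measured pair tests this replacement directly, so no shift beyond the scatter is expected, in either direction, though with wide uncertainty. The expected change is a 1.2-fold lower number from compound 2 to compound 3 (0.07 log units; within the scatter). Compound 3 is estimated at 13000 nM, with an expected range of 4500 nM to 38000 nM.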

Compound 3, half-maximal cytotoxic concentration: 113000 nM
Compound 3: middle estimate off by 8.7-fold (0.94 log units), on the low side; the measured number lies above the stated range.
By their numbers in this assay, from the lowest: compounds 1 and 2 (each within the scatter of the next); then compound 3.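

In this assay the saturated chain carbon bound to an aromatic carbon proves far more sensitive than the two amines suggested: acetoxy in place of (3-hydroxypropyl)amino gives a 7.5-fold higher number from compound 2 to compound 3 (0.87 log units; beyond the scatter) and acetoxy in place of cyclopropylamino gives a 9.3-fold higher number from compound 1 to compound 3 (0.97 log units; beyond the scatter) with both steps beyond the scatter. Exchanging one amine substituent for the other had given only a 1.2-fold higher number from compound 1 to compound 2 (0.10 log units; within the scatter) and so stayed within the scatter, while replacing either amino group with acetoxy allows more compound to be tolerated. Nothing available explains this shift.

In both steps the amine nitrogen leaves as acetoxy enters, so the compounds shown leave open which of these two changes goes with the higher number. A hydroxyl or an acetamido group on the same carbon would help separate them.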